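The source may hold more compounds than are shown below. What is called first, only, known or untested is meant among the compounds shown, and "the series" means these compounds.

Compound 1 `Cc1ccccc1-n1cc(-c2ccccc2NS(=O)(=O)c2c[nH]c(=O)[nH]c2=O)nn1` and compound 2 `Cc1cccc(-n2cc(-c3ccccc3NS(=O)(=O)c3c[nH]c(=O)[nH]c3=O)nn2)c1` share one core and differ in a single place: 3-methylphenyl in place of 2-methylphenyl on an aromatic nitrogen. In a functional assay on HepG2 cells (Homo sapiens) for antiproliferative activity, read by MTT assay, with a stated time of 24 h (on this read-out higher numbers stand for weaker inhibition and lower numbers for stronger inhibition), compound 1 gives 13900 nM and compound 2 gives 3620 nM, so this change made a 3.8-fold lower number from compound 1 to compound 2 (0.58 log units; beyond the scatter). Compound 3 `Cc1ccccc1-n1cc(-c2cccc(NS(=O)(=O)c3c[nH]c(=O)[nH]c3=O)c2)nn1` carries the same 2-methylphenyl group on a different core; the difference between the two cores is not broken down here. In this assay compound 3 gives 9570 nM. Compound 4 `Cc1cccc(-n2cc(-c3cccc(NS(=O)(=O)c4c[nH]c(=O)[nH]c4=O)c3)nn2)c1` has not been measured and is related to compound 3 by the same change at the same place: 3-methylphenyl in place of 2-methylphenyl on an aromatic nitrogen. Because the earlier step was a 3.8-fold lower number from compound 1 to compound 2 (0.58 log units; beyond the scatter), a comparable step is expected, estimated at a 3.4-fold lower number from compound 3 to compound 4 (0.53 log units; beyond the scatter), with a wide band since it rests on one example. Compound 4 is therefore expected to give about 2800 nM in this assay, between 1200 nM and 7000 nM.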

Compound 4, half-maximal inhibitory concentration: 7050 nM
Compound 4: the middle estimate sits 2.5-fold (0.40 log units) below what was measured, and the stated range ends below it.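

In this assay, putting 3-methylphenyl in place of 2-methylphenyl on the second core gives a 1.4-fold lower number from compound 3 to compound 4 (0.13 log units; within the scatter), a step too small to separate from repeat-measurement noise. Among the compounds shown here, the change therefore does not carry over at the same size from one core to the other: the same change on two cores in this assay, a 3.8-fold lower number (0.58 log units; beyond the scatter) from compound 1 to compound 2 and a 1.4-fold lower number (0.13 log units; within the scatter) from compound 3 to compound 4, 2.8-fold (0.45 log units) apart, beyond the scatter of two such steps With only one pair on each core, this shows that the size of the step can depend on the core, but not why it does, nor what the step would be on a further core.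

The compounds shown leave open whether other groups on that ring nitrogen, such as an unsubstituted phenyl or a chlorophenyl, would also respond differently on the two cores. From the compounds shown here alone, whether the two steps would differ in other cell types also stays open.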